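Swapping the thioether heteroaryl in a cyclopropylmethoxy analogue

The source may report more compounds than this note shows. Statements on the series, on what has been measured and on what is new or still open speak of the compounds shown alone.

Measured compounds:
- compound 1, `CCOc1ccc(-c2c(C#N)c(N)nc(SCc3ccn[nH]3)c2C#N)cc1`: 21 nM
- compound 2, `N#Cc1c(N)nc(SCc2ccn[nH]2)c(C#N)c1-c1ccc(OCC2CC2)cc1`: 552 nM
- compound 3, `C=CCOc1ccc(-c2c(C#N)c(N)nc(SCc3ccn[nH]3)c2C#N)cc1`: 44 nM

All three share one core and differ only in the ether group on the aryl ring. In an assay on CHO cells for displacement of a labelled ligand from adenosine receptor A1 (Homo sapiens), read by scintillation counting, with a stated time of 90 min (on this read-out higher numbers stand for weaker inhibition and lower numbers for stronger inhibition), compound 2 gives the highest number of the three: the step of a 13-fold lower number from compound 2 to compound 3 (1.10 log units; beyond the scatter) is large, and the step of a 26-fold higher number from compound 1 to compound 2 (1.42 log units; beyond the scatter) is larger still, while a 2.1-fold higher number from compound 1 to compound 3 (0.32 log units; beyond the scatter) is modest. Compound 4, `N#Cc1c(N)nc(SCc2csc(N)n2)c(C#N)c1-c1ccc(OCC2CC2)cc1`, keeps the cyclopropylmethoxy group of compound 2 and changes the heteroaryl on the thioether instead: 2-amino-1,3-thiazol-4-yl in place of 1H-pyrazol-5-yl on a saturated chain carbon bound to a sulfur. Among the measured compounds shown here, no measured pair varies this part of the molecule; every measured step concerns the ether group alone, so none of them bears directly on the change. For the measured compounds named here, with no precedent in these data, the step of a 1.1-fold lower number from compound 2 to compound 4 (0.04 log units; within the scatter) is expected to be small, within the scatter in either direction. Compound 4 is therefore estimated at 500 nM in this assay, with a range from 150 nM to 2000 nM.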

Compound 4, inhibition constant: 140 nM
For compound 4 the middle estimate is 3.6-fold (0.55 log units) above the measured one, outside the stated range (below it).
By their numbers in this assay, from the lowest: compound 1; then compound 3; then compound 4; then compound 2.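

The heteroaryl on the thioether proves to be a second place that moves the number in this assay: with the cyclopropylmethoxy group held fixed, 2-amino-1,3-thiazol-4-yl in place of 1H-pyrazol-5-yl gives a 3.9-fold lower number from compound 2 to compound 4 (0.60 log units; beyond the scatter). The earlier steps shown here all concerned the ether group, so they could not show that a change on the saturated chain carbon bound to a sulfur also shifts the number beyond the scatter, though here only modestly. Nothing available accounts for the direction or size of this step.

On these data alone, it remains open whether the same swap would lower the number with the ethoxy group of compound 1 or the allyloxy group of compound 3. Also open, as far as these compounds go, is how much of the step depends on the amino group, which a plain 1,3-thiazol-4-yl or a phenyl at this place would help to test.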